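Trimethoxyphenyl pyrazole enones: trimming a methoxy on the ketone aryl

The source may report more compounds than this note shows. Statements on the series, on what has been measured and on what is new or still open speak of the compounds shown alone.

Measured compounds in a functional assay on MDA-MB-468 cells (Homo sapiens) for inhibition, read by sulforhodamine B assay, with a stated time of 48 h; a lower number here means a stronger inhibitor of growth, a higher number a weaker inhibitor of growth:
compound 1 `COc1cc(-c2cc(/C=C/C(=O)c3ccc(N)cc3)[nH]n2)cc(OC)c1OC` gives 2910 nM
compound 2 `COc1ccc(C(=O)/C=C/c2cc(-c3cc(OC)c(OC)c(OC)c3)n[nH]2)cc1OC` gives 2180 nM

Compound 2 stands lowest of the two numbers in this assay, but the step of a 1.3-fold lower number from compound 1 to compound 2 (0.13 log units; within the scatter) is within the scatter, so nothing separates compound 2 from compound 1. Compound 3 `COc1ccc(C(=O)/C=C/c2cc(-c3cc(OC)c(OC)c(OC)c3)n[nH]2)cc1` has not yet been measured. It differs from compound 2 by hydrogen in place of methoxy on an aromatic carbon. Going by the values given here, no measured step removes a methoxy group; the only step in hand, a 1.3-fold lower number from compound 1 to compound 2 (0.13 log units; within the scatter), exchanged the whole aryl on the carbonyl carbon and stayed within the scatter, so the record gives no size for a change of this kind and no sign that the ring on the carbonyl carbon sets the number. For compound 3 the expected step is a 1.1-fold higher number from compound 2 to compound 3 (0.06 log units; within the scatter) in this assay, with no direction beyond the scatter. The estimate for compound 3 is 2500 nM, in the range 900 nM to 7000 nM.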

Compound 3, concentration for total growth inhibition: 2650 nM
Beside the measured number, compound 3's estimate is 1.1-fold (0.03 log units) below it; the range from low to high includes it.
By their numbers in this assay, from the lowest: compounds 2, 3 and 1 (each within the scatter of the next).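

In this assay, taking off one methoxy group (3,4-dimethoxyphenyl to 4-methoxyphenyl) gives a step that stays within the scatter (a 1.2-fold higher number from compound 2 to compound 3 (0.08 log units; within the scatter)), so this position shows no readable dependence on that methoxy group. Methoxy in place of amino on the aromatic carbon also stays within the scatter (a 1.1-fold lower number from compound 1 to compound 3 (0.04 log units; within the scatter)), so 4-aminophenyl, 4-methoxyphenyl and 3,4-dimethoxyphenyl on the carbonyl carbon are not separated by these numbers. No available evidence bears on this result.

On these data alone, all three groups tested on the carbonyl carbon are aryl rings carrying amino or methoxy, so it remains open whether a carboxylic acid or a longer ether chain such as butoxy on that ring would move the number beyond the scatter. As far as these compounds go, the trimethoxyphenyl group is common to all three compounds, so what its methoxy groups contribute also remains open.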